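Swapping an Anilino Group for a Pyrrolidine Ring

A few compounds are considered here, and "the series" means these few. Any claim that something is new, unique, unknown or untested is made for them only; others in the source may bear on it.

Going by the values given here, compound 1 `O=C1C=C(Nc2ccccc2F)C(=O)c2c1nc1n2[C@H]2OC[C@@H](O)[C@H]2OC1` is the one member of this small set with a measured number. In a functional assay on ECa-109 cells for inhibition, with ECa-109 cell line (Homo sapiens) as the target, read by sulforhodamine B assay (a higher number here means a weaker inhibitor, a lower number a stronger inhibitor), compound 1 gives 2760 nM. Compound 2 `CCCN(CCC)C1=CC(=O)c2c(nc3n2[C@H]2OC[C@@H](O)[C@H]2OC3)C1=O` is a close relative carrying a dipropylamino group. In this assay compound 2 reaches only > 16000 nM, which is a limit of the assay and not a number. Compound 3 `O=C1C=C(N2CCCC2)C(=O)c2c1nc1n2[C@H]2OC[C@@H](O)[C@H]2OC1` is the compound still to be measured. It differs from compound 1 in one place: pyrrolidin-1-yl in place of (2-fluorophenyl)amino on a double-bonded ring carbon. The hydrogen-bond donor leaves, and a five-membered non-aromatic ring with one hetero atom enters. Compound 3 is expected to be a weaker inhibitor, because compound 2 with its dialkylamino group sits at the limit of > 16000 nM in this assay, at which 1 of the 2 values shown sits. The expected step of a 4.3-fold higher number from compound 1 to compound 3 (0.64 log units; beyond the scatter) is a clear weakening, beyond the usual scatter. Compound 3 is estimated at 12000 nM, between 4000 nM and 40000 nM.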

Compound 3, half-maximal inhibitory concentration: > 16000 nM
Compound 3: a limit, no number; the forecaster's own chance of this, stated with the estimate: 45%; at least 1.3-fold (0.12 log units) between middle value and limit.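

In this assay, going by these compounds alone, replacing (2-fluorophenyl)amino with pyrrolidin-1-yl gives the first single-place step at this double-bonded ring carbon, and it is a clear loss: an at least 5.7-fold higher number from compound 1 to compound 3 (0.76 log units; beyond the scatter). The value of compound 3 is a limit of the assay and not a number. With pyrrolidin-1-yl, as with the dipropylamino group of compound 2, the reading stops at the same limit: the limit of > 16000 nM in this assay, at which 2 of the 3 values shown sit.

This one change removes the hydrogen-bond donor and the aromatic ring together, so the compounds shown cannot tell which of the two losses counts. A propylamino group, which keeps the donor without the aromatic ring, or a methyl(phenyl)amino group, which keeps the aromatic ring without the donor, would separate the two.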